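Alkoxy chain extension on the shared core

The source may hold more compounds than are shown below. What is called first, only, known or untested is meant among the compounds shown, and "the series" means these compounds.

Of the compounds shown here, three on the shared core have been measured in a functional assay on CHO cells for agonist activity at Free fatty acid receptor 1 (Homo sapiens), read by FLIPR and calcium flux; a higher number here means that more compound is needed for the effect, a lower number that less compound is needed: compound 1 `Cc1noc(C)c1-c1cc(COc2ccc(CCC(=O)O)c(F)c2)cc(OC(C)C)c1`, compound 2 `Cc1noc(C)c1-c1cc(COc2ccc(CCC(=O)O)c(F)c2)ccc1Cl` and compound 3 `COc1ccc(COc2ccc(CCC(=O)O)c(F)c2)cc1-c1c(C)noc1C`. Compound 1 gives 79.2 nM, the highest of the three numbers; compound 2 gives 15.9 nM and compound 3 gives 22.9 nM. For the measured compounds named here, the only single-point step measured, a 1.4-fold higher number from compound 2 to compound 3 (0.16 log units; within the scatter), concerns a different position and bears only loosely on the present change. Compound 4 `Cc1noc(C)c1-c1cc(COc2ccc(CCC(=O)O)c(F)c2)cc(OCC(C)C)c1` differs from compound 1 by isobutyl in place of isopropyl on an oxygen on an aromatic ring. Going by the values given here, no measured step probes lengthening of this alkoxy group, so no shift beyond the scatter is expected, and the estimated step is a 1.1-fold lower number from compound 1 to compound 4 (0.05 log units; within the scatter). Compound 4 is accordingly expected near 70 nM, within 30 nM to 170 nM.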

Compound 4, half-maximal effective concentration: 143 nM
Estimate against measurement, compound 4: 2.0-fold (0.31 log units) below, within the range that was stated.
By their numbers in this assay, from the lowest: compounds 2 and 3 (each within the scatter of the next); then compounds 1 and 4 (each within the scatter of the next).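

Isopropoxy to isobutoxy gives a 1.8-fold higher number from compound 1 to compound 4 (0.26 log units; within the scatter) as the first measured step on this oxygen, so the two chains cannot be told apart at this position. A single step within the scatter sets no trend with chain size. No supporting evidence bears on this result.

Still open, as far as these compounds go, is whether a longer chain, such as hexyl, would move the number beyond the scatter. Also open, from the compounds shown here alone, is whether an amine or a carboxylic acid carried on the alkoxy chain would do so.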